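Lipophilicity of a Cyclohexyl Pyrrolidine Analogue

A few compounds are considered here, and "the series" means these few. Any claim that something is new, unique, unknown or untested is made for them only; others in the source may bear on it.

Three compounds sharing one core were measured in a physicochemical assay for lipophilicity; on this read-out lower numbers stand for lower lipophilicity and higher numbers for higher lipophilicity. Compound 1 `N[C@H]1CC[C@H](Nc2ccc3ncc(-c4cnc(Nc5ncccc5F)nc4)n3n2)CC1` gives 0.2, compound 2 `Fc1cccnc1Nc1ncc(-c2cnc3ccc(N[C@H]4CCNC4)nn23)cn1` gives 0.4, and compound 3 `CN1CCN(CCNc2ccc3ncc(-c4cnc(Nc5ncccc5F)nc4)n3n2)CC1` gives 1.6, the highest of the three. The step of a number 1.40 log units higher from compound 1 to compound 3 (beyond the scatter) and the step of a number 1.20 log units higher from compound 2 to compound 3 (beyond the scatter) both set compound 3 clearly apart, while the step of a number 0.20 log units higher from compound 1 to compound 2 (within the scatter) is within the scatter.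

Compound 4 `Fc1cccnc1Nc1ncc(-c2cnc3ccc(N[C@H]4CC[C@H](N5CCCC5)CC4)nn23)cn1` is unmeasured. It differs from compound 3 by 4-(pyrrolidin-1-yl)cyclohexyl in place of 2-(4-methylpiperazin-1-yl)ethyl on a nitrogen on an aromatic ring. Within the data shown here, no measured step covers this exact change. The step of a number 1.40 log units higher from compound 1 to compound 3 (beyond the scatter) bears on it most, since compound 1 carries a cyclohexyl group on the same nitrogen and sits far below compound 3; compound 4 keeps a cyclohexyl group but with a pyrrolidine ring where compound 1 has an amino group, and its pattern of counted acceptors and nitrogens lies closer to compound 3. On this basis compound 4 is expected to stay near the upper end of the observed numbers, with a step of a number 0.30 log units higher from compound 3 to compound 4 (within the scatter) that may not exceed the scatter. The estimate for compound 4 in this assay is 1.9, expected within 1.2 to 2.6.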

Compound 4, distribution coefficient: 1.9
Compound 4: the middle estimate sits on the measured number at the digits printed; measured number inside the range.
By their numbers in this assay, from the lowest: compounds 1 and 2 (each within the scatter of the next); then compounds 3 and 4 (each within the scatter of the next).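

In this assay, changing amino to pyrrolidin-1-yl on a saturated ring carbon while keeping the cyclohexyl ring gives a number 1.70 log units higher from compound 1 to compound 4 (beyond the scatter) and so shows that a cyclohexyl group on this nitrogen does not by itself keep the number low. Set against the 2-(4-methylpiperazin-1-yl)ethyl group, the 4-(pyrrolidin-1-yl)cyclohexyl group gives a number 0.30 log units higher from compound 3 to compound 4 (within the scatter) even though the two differ in their rings, one having a six-membered non-aromatic ring with 2 hetero atoms and the other a five-membered ring with 1 hetero atom plus a six-membered ring of carbon only. The same group set against pyrrolidin-3-yl gives a number 1.50 log units higher from compound 2 to compound 4 (beyond the scatter) and, with the other steps, divides the compounds at this position into two sets, compound 1 with compound 2 and compound 3 with compound 4.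

No measurement at hand accounts for any of these differences. Going by these compounds, it remains open whether a morpholine ring, a carboxylic acid or a longer chain on the cyclohexyl ring, in place of the pyrrolidin-1-yl group, would leave the number at the level of compound 4 or return it to that of compound 1.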